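This account rests on a few compounds, and the source may have more. Where it says the series, first, only, none or still open, it means among the compounds named here.

Measured so far in a functional assay on SMMC-7721 cells (Homo sapiens) for cytotoxicity, read by MTT assay, with a stated time of 4 days; on this read-out lower numbers stand for stronger inhibition and higher numbers for weaker inhibition:
compound 1 `C=C1C(=O)[C@]23C[C@@]1(O)CC[C@H]2c1ccc(O)c(C)c1[C@@H]3Cn1cc(-c2ccc(Br)cc2)nn1` gives 1300 nM
compound 2 `C=C1C(=O)[C@]23C[C@@]1(O)CC[C@H]2c1ccc(OS(=O)(=O)c2ccc(C)cc2)c(C)c1[C@@H]3Cn1cc(-c2ccc(Br)cc2)nn1` gives 4320 nM
compound 3 `C=C1C[C@]23C[C@@]1(O)CC[C@H]2c1cc(Br)c(O)c(C)c1[C@@H]3Cn1cc(-c2ccc(C(F)(F)F)cc2)nn1` gives 12800 nM

Compound 1 stands lowest of the three numbers. Compound 2 lies a 3.3-fold higher number from compound 1 to compound 2 (0.52 log units; beyond the scatter) away, and compound 3 is further still, its value and that of compound 1 lying well apart. Going by the values given here, the only single-place step recorded, (4-methylphenyl)sulfonyl in place of hydrogen on an oxygen on an aromatic ring, concerns a different part of the shared core and leaves the aryl on the triazole untouched.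

Compound 4 `C=C1C(=O)[C@]23C[C@@]1(O)CC[C@H]2c1ccc(O)c(C)c1[C@@H]3Cn1cc(-c2ccc(F)cc2)nn1` is not yet measured. It differs from compound 1 by fluoro in place of bromo on an aromatic carbon, which read one bond further out is 4-bromophenyl to 4-fluorophenyl. Among the compounds with values here, no measured pair changes only this group. Compound 3 carries a trifluoromethyl on that ring but differs from compound 1 in two further places, so its number cannot be assigned to the aryl change alone. Within the data shown here, the data therefore give no direction for this step; a change within or just beyond the usual scatter in this assay is the plain reading, with a slight lean toward a higher number since compound 3, the only other variant at this ring, gives 12800 nM.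

Compound 4 is expected to give about 1900 nM, within 800 nM to 4500 nM. This estimate means an expected step of a 1.5-fold higher number from compound 1 to compound 4 (0.16 log units; within the scatter).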

Compound 4, half-maximal inhibitory concentration: 850 nM
Beside the measured number, compound 4's estimate is 2.2-fold (0.35 log units) above it, and the stated range covers the measured number.
By their numbers in this assay, from the lowest: compounds 4 and 1 (each within the scatter of the next); then compound 2; then compound 3.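

In this assay the change from 4-bromophenyl to 4-fluorophenyl can now be read on its own: fluoro in place of bromo gives a 1.5-fold lower number from compound 1 to compound 4 (0.18 log units; within the scatter) and thus lies within the scatter, so these two halogens on an aromatic carbon, para to a large group, cannot be told apart in this read-out. Going by these compounds alone, this is the first single-place reading at this ring, since the only earlier step, with (4-methylphenyl)sulfonyl in place of hydrogen on an oxygen on an aromatic ring, gave a 3.3-fold higher number from compound 1 to compound 2 (0.52 log units; beyond the scatter) at a different part of the shared core and lay beyond the scatter. No measured evidence is available to explain the result.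

Compound 3 carries trifluoromethyl on this ring but differs from compound 1 in two further places, so it does not show what trifluoromethyl alone does here. Still open, as far as these compounds go, is whether the number stays in this range with a non-halogen group at this place, such as an amine, a carboxylic acid or a methoxy group, or with plain hydrogen in place of the halogen.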